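Trimming one methoxy from a chalcone-like pyrazole series

This account rests on a few compounds, and the source may have more. Where it says the series, first, only, none or still open, it means among the compounds named here.

Of the compounds shown here, three from one series have been tested in a functional assay on UACC-257 cells (Homo sapiens) for cytotoxicity, read by sulforhodamine B assay, with a stated time of 48 h, tested at 10 uM; a lower number here means a stronger effect, a higher number a weaker effect of the compound at the concentration tested. Compound 1 `COc1ccc(-c2cc(/C=C/C(=O)c3ccc(N)cc3)[nH]n2)cc1` gives -54%. Compound 2 `COc1cc(-c2cc(/C=C/C(=O)c3ccc(N)cc3)[nH]n2)cc(OC)c1OC` gives -59%, and compound 3 `COc1cc(-c2cc(/C=C/C(=O)c3ccc(F)c(F)c3)[nH]n2)cc(OC)c1OC` gives -18%. Among the compounds with values here, compound 2 sits at the low end of these three numbers; compound 1 lies within the scatter of it, while compound 3 lies well beyond, as the single step shows: a number 41 percentage points higher from compound 2 to compound 3 (beyond the scatter). That step concerns the group on the carbonyl carbon, not the ring carrying the methoxy groups, so it does not bear directly on the change examined here.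

Compound 4 `COc1ccc(-c2cc(/C=C/C(=O)c3ccc(N)cc3)[nH]n2)cc1OC` differs from compound 2 as follows: hydrogen in place of methoxy on an aromatic carbon, so that a methoxy group leaves and a hydrogen enters, ortho to a methoxy group and meta to another. Within the data shown here, no measured step isolates this change. The nearest guide is the pair of compound 1 and compound 2, which carry one and three methoxy groups and give numbers within the scatter of each other. An unremarkable step, a number 3 percentage points higher from compound 2 to compound 4 (within the scatter), is therefore expected, and compound 4 is estimated at -56%, between -72% and -38%.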

Compound 4, a percentage reported as activity, at one concentration (the size of the read-out at that concentration, not a potency): 39%
Estimate against measurement, compound 4: 95 percentage points below; measured number above the stated range.
By their numbers in this assay, from the lowest: compounds 2 and 1 (each within the scatter of the next); then compound 3; then compound 4.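

In this assay, a single methoxy group turns out to matter a great deal: hydrogen in place of methoxy gives a number 98 percentage points higher from compound 2 to compound 4 (beyond the scatter), while methoxy in place of hydrogen at another place on the same ring gives a number 93 percentage points higher from compound 1 to compound 4 (beyond the scatter). The effect of one methoxy group therefore depends on which others share the ring, and the number of methoxy groups alone does not order these compounds, since compound 4 stands apart from both of its one-step partners. No measurement shown here explains this jump.

On these data alone, it remains open whether methoxy itself is needed on this aromatic carbon, or whether a hydroxyl group or a chlorine atom there would restore the effect of compound 2. As far as these compounds go, the same change on compound 3, with its 3,4-difluorophenyl group, also remains open.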